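The compounds below may be only part of what the source reports. "The series", "measured", "known", "first", "only" and "open" are said of these compounds alone.

Working notes on the series.

Compound 2 `COc1cc(N2C(N)=C(C#N)C(c3ccc(C)o3)C3=C2CC(C)(C)CC3=O)cc(OC)c1OC` gives 31% in a functional assay on Ehrlich cells (Mus musculus) for cytotoxicity, tested at 25 ug/mL; a lower number here means a weaker effect, a higher number a stronger effect of the compound at the concentration tested. Among the compounds with values here, that is the higher of the two numbers so far; the nearest is compound 1 `COc1cc(N2C(N)=C(C#N)C(c3ccccc3O)C3=C2CC(C)(C)CC3=O)cc(OC)c1OC`, which in this assay gives 0%. Within the data shown here, the one step measured between them, a number 31 percentage points higher from compound 1 to compound 2 (beyond the scatter), came with 5-methylfuran-2-yl in place of 2-hydroxyphenyl on a saturated ring carbon.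

Compound 3 `COc1cc(N2C(N)=C(C#N)C(c3ccc(O)cc3)C3=C2CC(C)(C)CC3=O)cc(OC)c1OC` is not yet measured. It differs from compound 2 in one place: 4-hydroxyphenyl in place of 5-methylfuran-2-yl on a saturated ring carbon. The step bearing on this is a number 31 percentage points higher from compound 1 to compound 2 (beyond the scatter), which was large and ran toward the 5-methylfuran-2-yl now leaving. Among the measured compounds shown here, compound 3 carries 4-hydroxyphenyl rather than the 2-hydroxyphenyl of compound 1, so no measured step matches it exactly. A step in this assay of about a number 21 percentage points lower from compound 2 to compound 3 (beyond the scatter) is expected, downward, going back toward the lower number. For compound 3 the value expected in this assay is 10%, within 0% to 30%.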

Compound 3, a percentage reported as activity, at one concentration (the size of the read-out at that concentration, not a potency): 20%
Compound 3: middle estimate off by 10 percentage points, on the low side; measured number inside the range.
By their numbers in this assay, from the lowest: compound 1; then compound 3; then compound 2.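

At this saturated ring carbon the two hydroxyphenyl groups do not read alike in this assay: 4-hydroxyphenyl in place of 2-hydroxyphenyl gives a number 20 percentage points higher from compound 1 to compound 3 (beyond the scatter) and so the outcome depends on where the hydroxyl stands on the phenyl ring, not only on the ring being a phenyl. Within the data shown here, the five-membered ring is also not the only group here that lifts the number above that of compound 1, although 4-hydroxyphenyl in place of 5-methylfuran-2-yl still gives a number 11 percentage points lower from compound 2 to compound 3 (beyond the scatter) and leaves 5-methylfuran-2-yl on top of the three. Nothing available accounts for either step.

Open, as far as these compounds go, is what a plain phenyl, or an amine or carboxylic acid in place of the hydroxyl, would give at this carbon. Also open, from the compounds shown here alone, is whether furan-2-yl without the methyl would match compound 2.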